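Adding a Side Chain to the Core of Compound 2

The source may report more compounds than this note shows. Statements on the series, on what has been measured and on what is new or still open speak of the compounds shown alone.

Two compounds share one core and differ only in the halogen on one aromatic carbon. In an assay on tissue (HeLa cells) for inhibition of Indoleamine 2,3-dioxygenase 1 (Homo sapiens), read by spectrophotometry (on this read-out lower numbers stand for stronger inhibition and higher numbers for weaker inhibition), compound 1 `O/N=C(/Nc1cccc(F)c1)c1ccc2occc2c1` gives 20000 nM, while compound 2 `O/N=C(/Nc1cccc(Br)c1)c1ccc2occc2c1` gives 1100 nM; the step of an 18-fold lower number from compound 1 to compound 2 (1.26 log units; beyond the scatter) leaves compound 2 with the lower of the two numbers. Compound 3 `O/N=C(/Nc1cccc(Br)c1)c1ccc2oc(COCC3CC3)cc2c1` keeps the bromo group and changes the core instead: (cyclopropylmethoxy)methyl in place of hydrogen on an aromatic carbon. Going by the values given here, the single measured step concerns the halogen and does not bear on this new position, so no measured guide exists. Compound 3 is therefore expected to give about 1000 nM, with a range of 250 nM to 4000 nM. The expected step of a 1.1-fold lower number from compound 2 to compound 3 (0.04 log units; within the scatter) lies within the scatter.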

Compound 3, half-maximal inhibitory concentration: 3200 nM
Estimate against measurement, compound 3: 3.2-fold (0.51 log units) below; measured number inside the range.
By their numbers in this assay, from the lowest: compound 2; then compound 3; then compound 1.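

In this assay, placing (cyclopropylmethoxy)methyl on the aromatic carbon next to the ring oxygen gives a 2.9-fold higher number from compound 2 to compound 3 (0.46 log units; beyond the scatter), so this position is not indifferent to change, although the loss is modest. It also shows that the core of compound 2 can carry this side chain and still give a measurable number. Nothing available explains the shift. Still open, as far as these compounds go, is whether a shorter chain such as methoxymethyl, an amine or a carboxylic acid at this position would give a lower number. From the compounds shown here alone, whether the side chain acts the same way with fluoro in place of bromo also remains open.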